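Removing an ester from a macrolide: expected lipophilicity of compound 4

The source may hold more compounds than are shown below. What is called first, only, known or untested is meant among the compounds shown, and "the series" means these compounds.

Compound 1 `CC[C@H]1OC(=O)[C@H](C)[C@@H](O[C@H]2C[C@@](C)(OC)[C@@H](OC(=O)CN(CC)CC)[C@H](C)O2)[C@H](C)[C@@H](O[C@@H]2O[C@H](C)C[C@H](N(C)C)[C@H]2O)[C@](C)(OC)C[C@@H](C)C(=O)N[C@H](C)[C@@H](O)[C@]1(C)O` stands at the top of the three numbers available in a physicochemical assay for lipophilicity, read by HPLC, measured as chromatographic lipophilicity, at pH 7.4 (a lower number here means a more polar compound, a higher number a more lipophilic compound), where compound 1 gives 3.86. Compound 3 `CC[C@H]1OC(=O)[C@H](C)[C@@H](O[C@H]2C[C@@](C)(OC)[C@@H](O)[C@H](C)O2)[C@H](C)[C@@H](O[C@@H]2O[C@H](C)C[C@H](N(C)C)[C@H]2OCCCNC(=O)c2c(C)nn(C)c2Cl)[C@](C)(O)C[C@@H](C)CN(C)[C@H](C)[C@@H](O)[C@]1(C)O` is the nearest of the other two; in this assay compound 3 gives 3.08, a value beyond the scatter below compound 1. Compound 2 `CC[C@H]1OC(=O)[C@H](C)[C@@H](O)[C@H](C)[C@@H](O)[C@](C)(O)C[C@@H](C)CN(C)[C@H](C)[C@@H](O)[C@]1(C)O`, the smallest of the set, lies furthest away; in this assay compound 2 gives 1.29. No pair among these three differs in a single place, so none of the gaps between them can be read as the effect of one change.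

Compound 4 `CC[C@H]1OC(=O)[C@H](C)[C@@H](O[C@H]2C[C@@](C)(OC)[C@@H](O)[C@H](C)O2)[C@H](C)[C@@H](O[C@@H]2O[C@H](C)C[C@H](N(C)C)[C@H]2O)[C@](C)(OC)C[C@@H](C)C(=O)N[C@H](C)[C@@H](O)[C@]1(C)O` has not yet been measured. It differs from compound 1 in one place: hydrogen in place of ((diethylamino)methyl)carbonyl on an oxygen on a saturated carbon. The change removes eight heavy atoms, among them a basic nitrogen, and turns an ester into a hydroxy group. On the evidence at hand, the smaller, more oxygen-rich compounds sit lower in this assay, so a fall beyond the scatter is the expected direction for compound 4. The author therefore estimates for compound 4 a value of 3.2, within a range from 2.6 to 3.8, which would mean an expected step of a number 0.66 log units lower from compound 1 to compound 4 (beyond the scatter).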

Compound 4, distribution coefficient: 2.41
For compound 4 the middle estimate is 0.79 log units above the measured one, and the stated range ends above it.
By their numbers in this assay, from the lowest: compound 2; then compound 4; then compound 3; then compound 1.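

With compound 4, the set gains its first pair that differs in one place, so the ((diethylamino)methyl)carbonyl on an oxygen on a saturated carbon can now be read on its own: exchanging it for hydrogen gives a number 1.45 log units lower from compound 1 to compound 4 (beyond the scatter) in this assay. This position is therefore not a silent one on the core of compound 1, since a single change there moves the reading well beyond the scatter. The single step shows only the size and direction of this exchange, and nothing shown here explains why it is this large.

The pair cannot separate the share of the diethylamine from that of the ester, and a plain acetyl ester on the same oxygen, carrying no amine, would divide the step between the two, while a longer chain between the carbonyl and the diethylamine or a carboxylic acid in place of the amine would test how far the step depends on what the ester carries. As far as these compounds go, whether a similar step appears on another core also remains open, as compound 2 and compound 3 have no partner that differs from them in one place.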